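The compounds below may be only part of what the source reports. "The series", "measured", "known", "first", "only" and "open" are said of these compounds alone.

Measured so far:
compound 1 `N#Cc1cnc(NCc2cnccc2C(F)(F)F)cc1N[C@H]1C[C@@H](O)C1`: > 10000 nM
compound 2 `N#Cc1cnc(NCc2ccccc2C(F)(F)F)cc1N[C@H]1C[C@H](C(N)=O)C1`: > 10000 nM

In an assay on isolated protein for inhibition of protein kinase C delta type (Homo sapiens), read by TR-FRET, with a stated time of 2 h (on this read-out lower numbers stand for stronger inhibition and higher numbers for weaker inhibition), compound 1 gives > 10000 nM, a limit of the assay rather than a number. Compound 2 likewise gives only a limit, > 10000 nM. All evidence so far amounts to the limit of > 10000 nM in this assay, at which 2 of the 2 values shown sit, so compound 1 stands nowhere definite among the numbers shown. Compound 3 `CC1(C)[C@H](Nc2cc(NCc3cnccc3C(F)(F)F)ncc2C#N)C[C@H]1C(N)=O` is not yet measured; it differs from compound 1 by 3-carbamoyl-2,2-dimethylcyclobutyl in place of 3-hydroxycyclobutyl on a nitrogen on an aromatic ring. Going by the values given here, no measured pair isolates this change. Compound 3 is expected to show a step of a number no higher from compound 1 to compound 3 (the limit leaves the size open), none beyond the scatter, and will probably again return only a limit. The estimate for compound 3 is 10000 nM, ranging from 3000 nM to 30000 nM.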

Compound 3, half-maximal inhibitory concentration: 900 nM
For compound 3 the middle estimate is 11-fold (1.05 log units) above the measured one; the measured number lies below the stated range.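

In this assay, the change from (3-hydroxycyclobutyl)amino to (3-carbamoyl-2,2-dimethylcyclobutyl)amino gives an at least 11-fold lower number from compound 1 to compound 3 (1.04 log units; beyond the scatter). This position on the shared core can therefore bring the read-out off the limit, and compound 3 is the only compound shown with a number. The value for compound 1 is a limit, so the step has only a lower bound: the limit of > 10000 nM in this assay, at which 2 of the 3 values shown sit.

It remains open whether the carbamoyl group or the two methyl groups carry the step, as no compound shown separates them. A carboxylic acid or an amine in place of the carbamoyl group also remains untested among the compounds shown.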